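The source may hold more compounds than are shown below. What is called first, only, known or untested is meant among the compounds shown, and "the series" means these compounds.

Compound 1, `O=C(O)C[C@H](CCCCCCc1ccc2c(n1)NCCC2)c1cncnc1`, gives 3.9 mL/min/kg in an in vivo ADME assay on the whole organism (Canis lupus familiaris) for pharmacokinetics; on this read-out lower numbers stand for slow clearance and higher numbers for fast clearance; compound 2, `O=C(O)C[C@H](CCCCCCc1ccc2c(n1)NCCC2)c1cnc2ccccc2c1`, gives 3 mL/min/kg.

Compound 2 holds the lowest of the two numbers, with compound 1 nearest, though the step of a 1.3-fold lower number from compound 1 to compound 2 (0.11 log units; within the scatter) sits within the scatter. Compound 3, `COc1ncc([C@@H](CCCCCCc2ccc3c(n2)NCCC3)CC(=O)O)cn1`, is not yet measured. It differs from compound 2 by 2-methoxypyrimidin-5-yl in place of quinolin-3-yl on a saturated chain carbon bound to two saturated chain carbons. For the measured compounds named here, the one measured step at this place, from compound 1 to compound 2, changed little, so a swap back to a pyrimidine ring is expected to move the number no further than the scatter: a 1.3-fold higher number from compound 2 to compound 3 (0.12 log units; within the scatter). Compound 3 is therefore estimated at 4 mL/min/kg, between 2 mL/min/kg and 8 mL/min/kg.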

Compound 3, clearance in the Canis lupus familiaris assay: 4.3 mL/min/kg
Compound 3: the middle estimate sits 1.1-fold (0.03 log units) below what was measured; the range from low to high includes it.
By their numbers in the Canis lupus familiaris assay, from the lowest: compounds 2, 1 and 3 (each within the scatter of the next).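

In the Canis lupus familiaris assay, replacing quinolin-3-yl with 2-methoxypyrimidin-5-yl gives only a 1.4-fold higher number from compound 2 to compound 3 (0.16 log units; within the scatter), and methoxy in place of hydrogen on an aromatic carbon gives only a 1.1-fold higher number from compound 1 to compound 3 (0.04 log units; within the scatter). In a physicochemical assay for lipophilicity (on this read-out lower numbers stand for lower lipophilicity and higher numbers for higher lipophilicity), however, compound 2 gives 2.39 and compound 3 gives 0.65. At this place, then, a large difference in partition coefficient comes with no clearance difference that can be read beyond the scatter.

On these data alone, whether an amine or a fluorine in place of the methoxy would move clearance beyond the scatter remains open.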